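A few compounds are considered here, and "the series" means these few. Any claim that something is new, unique, unknown or untested is made for them only; others in the source may bear on it.

Compound 2 `C=CC(=O)Nc1cccc(NC(=O)CSc2nc(Nc3ccccc3)c3ccccc3n2)c1` gives 8740 nM in a functional assay on PC-3 cells (Homo sapiens) for inhibition, read by MTT assay, with a stated time of 72 h; a lower number here means a stronger inhibitor, a higher number a weaker inhibitor. Going by the values given here, the only comparison available is compound 1 `COc1cccc(NC(=O)CSc2nc(Nc3ccccc3)c3ccccc3n2)c1`, which in this assay gives 11600 nM; the step of a 1.3-fold lower number from compound 1 to compound 2 (0.12 log units; within the scatter) is the single measured change, and it does not reach beyond the scatter. On the numbers shown, compound 2 therefore sits alongside compound 1 rather than apart from it.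

Compound 3 `O=C(CSc1nc(Nc2ccccc2)c2ccccc2n1)Nc1ccc([N+](=O)[O-])cc1` differs from compound 2 by 4-nitrophenyl in place of 3-((vinylcarbonyl)amino)phenyl on an amide-type nitrogen. That measured step touched the same amide-bound phenyl ring, exchanging one substituent for another, and left the number essentially unmoved; nothing measured speaks to a nitro group in that place. The expectation is accordingly a step of a 1.1-fold higher number from compound 2 to compound 3 (0.06 log units; within the scatter) of no size beyond the scatter, in no fixed direction. Compound 3 is estimated to give about 10000 nM, with a range from 3000 nM to 35000 nM.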

Compound 3, half-maximal inhibitory concentration: 25000 nM
For compound 3 the middle estimate is 2.5-fold (0.40 log units) below the measured one; low and high end bracket the measured number.
By their numbers in this assay, from the lowest: compounds 2 and 1 (each within the scatter of the next); then compound 3.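

In this assay, the step of a 2.9-fold higher number from compound 2 to compound 3 (0.46 log units; beyond the scatter) and the step of a 2.2-fold higher number from compound 1 to compound 3 (0.33 log units; beyond the scatter) show that a change on the amide-type nitrogen can move the number beyond the scatter, which the first two compounds did not show. Both steps are modest and run the same way, so 4-nitrophenyl gives the weakest inhibitor of the three, while 3-methoxyphenyl and 3-((vinylcarbonyl)amino)phenyl remain within the scatter of each other. Compound 3 changes both the substituent and the numbered place it occupies on the phenyl ring, so these compounds cannot separate the two.

On these data alone, how an amine or a carboxylic acid on this phenyl ring would read remains open. No measurement at hand gives a reason for these steps.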